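This account rests on a few compounds, and the source may have more. Where it says the series, first, only, none or still open, it means among the compounds named here.

Of the compounds shown here, three built on one shared core have been tested in a functional assay (aorta) with Rattus norvegicus as the target; a higher number here means a more potent compound, by a factor of ten per unit of this negative logarithm, a lower number a less potent compound. Compound 1 `CC1(C)C=C(n2ccccc2=O)c2cc(C(=O)c3cccs3)ccc2O1` gives 6.4. Compound 2 `CC1(C)C=C(n2ccccc2=O)c2cc(C(=O)c3ccccc3F)ccc2O1` gives 7.08, and compound 3 `CC1(C)C=C(n2ccccc2=O)c2cc(C(=O)c3ccccc3[N+](=O)[O-])ccc2O1` gives 6.17. Compound 3 carries the lowest of the three numbers, although its difference from compound 1, a number 0.23 log units lower from compound 1 to compound 3 (within the scatter), lies within the scatter; its distance from compound 2, a number 0.91 log units lower from compound 2 to compound 3 (beyond the scatter), is the only separation that is clearly real.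

Compound 4 `Cc1ccccc1C(=O)c1ccc2c(c1)C(n1ccccc1=O)=CC(C)(C)O2` differs from compound 3 in a single place: methyl in place of nitro on an aromatic carbon. The nitro leaves and a methyl enters on the same aromatic carbon. For the measured compounds named here, the one measured step that bears on this change is a number 0.91 log units lower from compound 2 to compound 3 (beyond the scatter), where a small fluoro group at that carbon stood clearly higher than nitro. Going by the values given here, no measured compound carries a methyl there, so the expectation rests on that single comparison and on the modest size of the other steps. Compound 4 is expected to give about 6.8, with a range from 6.2 to 7.4. The expected step is a number 0.63 log units higher from compound 3 to compound 4 (beyond the scatter), upward but short of what fluoro achieved.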

Compound 4, logarithm of the reciprocal of the active concentration, log(1/C): 6.83
For compound 4 the middle estimate is 0.03 log units below the measured one, within the range that was stated.
By their numbers in this assay, from the lowest: compounds 3 and 1 (each within the scatter of the next); then compounds 4 and 2 (each within the scatter of the next).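

In this assay, for the compounds shown here, fluoro is no longer the only group on this aromatic carbon that stands clearly above nitro, as methyl gives a number 0.66 log units higher from compound 3 to compound 4 (beyond the scatter) for the exchange of three heavy atoms for one. Methyl and fluoro cannot be told apart, with a number 0.25 log units lower from compound 2 to compound 4 (within the scatter) in this comparison, so among the three groups seen at this carbon, nitro alone stands apart. The 2-methylphenyl group also separates from thiophen-2-yl, with a number 0.43 log units higher from compound 1 to compound 4 (beyond the scatter) on the carbonyl carbon, which the 2-nitrophenyl group did not do.

Nothing measured here says why these groups differ. From the compounds shown here alone, it remains open whether a methoxy group or an amine on this carbon would match methyl and fluoro or fall to the level of nitro.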